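Aryl swap on the amide-type nitrogen: outlook for compound 3

A few compounds are considered here, and "the series" means these few. Any claim that something is new, unique, unknown or untested is made for them only; others in the source may bear on it.

Two compounds of the shared core have numbers in a functional assay on MDA-MB-231 cells (Homo sapiens) for cytotoxicity, read by MTT assay, with a stated time of 72 h; on this read-out higher numbers stand for weaker inhibition and lower numbers for stronger inhibition. Compound 1 `CN(C)CCNc1nc(-c2ccc(NC(=O)Nc3ccccc3F)cc2)nc2ccsc12` gives 600 nM. Compound 2 `CN(C)CCNc1nc(-c2ccc(NC(=O)Nc3ccccc3Cl)cc2)nc2ccsc12` gives 550 nM. Within the data shown here, the single measured step, a 1.1-fold lower number from compound 1 to compound 2 (0.04 log units; within the scatter), is within the scatter, so compound 2 holds the lowest of the two numbers without being separated from compound 1 beyond the scatter; on these two numbers the pair is level.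

Compound 3 `Cc1ccc(NC(=O)Nc2ccc(-c3nc(NCCN(C)C)c4sccc4n3)cc2)cc1` differs from compound 2 by 4-methylphenyl in place of 2-chlorophenyl on an amide-type nitrogen. Among the measured compounds shown here, the only measured step exchanges one halogen for another and bears on this change only loosely; no measured step exchanges a halogen for a methyl. In this assay the expected step is therefore one of no size beyond the scatter, a 1.1-fold higher number from compound 2 to compound 3 (0.04 log units; within the scatter), since nothing measured points either way. For compound 3 the estimate in this assay is 600 nM, with a range from 250 nM to 1500 nM.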

Compound 3, half-maximal inhibitory concentration: 2180 nM
Estimate against measurement, compound 3: 3.6-fold (0.56 log units) below, outside the stated range (above it).
By their numbers in this assay, from the lowest: compounds 2 and 1 (each within the scatter of the next); then compound 3.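

In this assay the aryl group on the amide-type nitrogen proves able to move the number: 4-methylphenyl in place of 2-chlorophenyl gives a 4.0-fold higher number from compound 2 to compound 3 (0.60 log units; beyond the scatter) and in place of 2-fluorophenyl gives a 3.6-fold higher number from compound 1 to compound 3 (0.56 log units; beyond the scatter) in the same direction. The halogen exchange alone, a 1.1-fold lower number from compound 1 to compound 2 (0.04 log units; within the scatter) in this assay, gave no sign of this, so the position is not indifferent to every aryl change. Nothing available explains the higher number of compound 3.

As far as these compounds go, the step to compound 3 removes the halogen, brings in a methyl and changes the substituent's place on the ring all at once, and which of these carries the step remains open. Also open, from the compounds shown here alone, is how an unsubstituted phenyl, a methoxy-bearing phenyl or an amine-bearing phenyl would read at this nitrogen.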